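The source may hold more compounds than are shown below. What is called first, only, known or untested is meant among the compounds shown, and "the series" means these compounds.

Working notes on the pyrazole series, assessed in a functional assay on MDA-MB-231 cells (Homo sapiens) for inhibition, read by sulforhodamine B assay, with a stated time of 48 h; on this read-out lower numbers stand for higher toxicity in this test and higher numbers for lower toxicity in this test.

Compound 1 `COc1cc(-c2nn(-c3cccc(NC(=O)c4cccc(C(F)(F)F)c4)c3)cc2-c2ccncc2)ccc1Cl` gives only a limit in this assay, > 50000 nM; that limit is where one of the three shown values sits (the limit of > 50000 nM in this assay, at which 1 of the 3 values shown sits). Compound 3 `COc1cc(-c2nn(-c3cccc(NC(=O)Nc4ccc(Cl)c(C(F)(F)F)c4)c3)cc2-c2ccncc2)ccc1Cl` gives 13300 nM, and the single-point comparison shows an at least 3.7-fold lower number from compound 1 to compound 3 (0.57 log units; beyond the scatter), with (4-chloro-3-(trifluoromethyl)phenyl)amino in place of 3-(trifluoromethyl)phenyl on a carbonyl carbon. Compound 2 `O=C(Nc1cccc(-n2cc(-c3ccncc3)c(-c3ccc(Cl)c(O)c3)n2)c1)Nc1cc(C(F)(F)F)cc(C(F)(F)F)c1` gives 3720 nM in this assay, the lowest of the two numbers shown; its nearest neighbour is compound 3, which sits a step beyond the scatter higher.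

Compound 4 `O=C(Nc1cccc(-n2cc(-c3ccncc3)c(-c3ccc(Cl)c(O)c3)n2)c1)Nc1cccc(C(F)(F)F)c1` is not yet measured. It differs from compound 2 by hydrogen in place of trifluoromethyl on an aromatic carbon, on a six-membered aromatic ring of carbon only, meta to a large group and meta to a trifluoromethyl group. Among the compounds with values here, no measured step in the set removes a trifluoromethyl group on an otherwise unchanged urea; the step from compound 1 to compound 3 changes both the linker and the aryl substitution, so it bears only loosely. With compound 2 at 3720 nM as the anchor, a modest move toward higher numbers is expected, a 2.4-fold higher number from compound 2 to compound 4 (0.38 log units; beyond the scatter), though a move within the scatter is also plausible.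

Compound 4 is therefore estimated at 9000 nM in this assay, with a range from 3000 nM to 30000 nM.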

Compound 4, concentration lethal to 50% of the cells: > 32500 nM
Compound 4: a limit, no number; the forecaster's own chance of this, stated with the estimate: 10%; middle value at least 3.6-fold (0.55 log units) away from the limit.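

Replacing one trifluoromethyl with hydrogen on the urea's aryl ring, meta to a large group and meta to a trifluoromethyl group, gives an at least 8.7-fold higher number from compound 2 to compound 4 (0.94 log units; beyond the scatter) in this assay, so this single place matters beyond the scatter in this pair. Within the data shown here, the one earlier step altered the linker as well as the aryl substitution, and so could say nothing of this trifluoromethyl alone. Compound 4 gives a limit and not a number, so the step has a lower bound but no measured size: the limit of > 32500 nM in this assay, at which 1 of the 4 values shown sits.

The compounds shown leave open whether a methyl group or a chlorine atom at this place would keep the read-out close to that of compound 2 or move it toward that of compound 4. They also leave open whether the same removal of trifluoromethyl would have a step of similar size on a urea that carries a methoxy group in place of the hydroxyl group of compound 2.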